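Cytotoxicity notes: the step from compound 2 to compound 4

A few compounds are considered here, and "the series" means these few. Any claim that something is new, unique, unknown or untested is made for them only; others in the source may bear on it.

Three members of the series have been examined in a functional assay on HeLa cells (Homo sapiens) for cytotoxicity, read by MTT assay, with a stated time of 24 h; on this read-out higher numbers stand for weaker inhibition and lower numbers for stronger inhibition. Compound 1 `O=c1nc2ccccn2cc1Cc1ccc(Br)cc1` reports only a limit, > 1000000 nM. Compound 2 `Cc1ccc(Cc2cn3cc(Cl)ccc3nc2=O)cc1` likewise reports only a limit in this assay, > 1000000 nM. Compound 3 `Nc1cccn2cc(Cc3ccccc3)c(=O)nc12` returns a number in this assay, 112000 nM. Among the compounds with values here, two of the three values thus sit at the limit of > 1000000 nM in this assay, at which 2 of the 3 values shown sit, and compound 2 is one of them: its value is a limit rather than a measurement, so it cannot be ranked against compound 1, and against compound 3 the data show only that compound 3 returned a number where compound 2 did not.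

Compound 4 `O=c1nc2ccc(Cl)cn2cc1Cc1ccc(F)cc1` has not yet been measured. Its change from compound 2 is fluoro in place of methyl on an aromatic carbon. Within the data shown here, no step between measured compounds touches this change, so the series gives no guide to its size. The expectation for compound 4 is no step beyond the scatter, a number no higher from compound 2 to compound 4 (the limit leaves the size open), with the read-out expected to be a limit again rather than a number. Compound 4 is estimated at 1000000 nM, within a range from 300000 nM to 3000000 nM.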

Compound 4, half-maximal inhibitory concentration: > 1000000 nM
Compound 4: no number, only a limit (the forecaster's own chance of this, stated with the estimate: 75%); the middle value lies on the limit itself.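

Compound 2 and compound 4 both report only limits in this assay, so no step between them can be read: the limit of > 1000000 nM in this assay, at which 3 of the 4 values shown sit.

The compounds shown leave open whether fluoro in place of methyl on an aromatic carbon shifts this read-out at all, and in which direction.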